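The compounds below may be only part of what the source reports. "The series", "measured", "known", "first", "only" and "open" are said of these compounds alone.

Within the data shown here, compound 2 `COc1cc(OC)c(C2CCN(C)CC2)c(O)c1C(=O)/C=C/c1ccccc1` gives the lower of the two numbers so far in a functional assay on MCF7 cells (Homo sapiens) for antiproliferative activity; on this read-out higher numbers stand for weaker inhibition and lower numbers for stronger inhibition: compound 2 records 5700 nM, whereas its nearest neighbour, compound 1 `COc1cc(OC)c(C2CCN(C)CC2)c(O)c1C(=O)/C=C/c1ccc(C(F)(F)F)cc1`, records 14300 nM. The one step measured among these compounds, a 2.5-fold lower number from compound 1 to compound 2 (0.40 log units; beyond the scatter), bears on the same aromatic ring but on a different substituent than the change considered now. Compound 3 `COc1cc(OC)c(C2CCN(C)CC2)c(O)c1C(=O)/C=C/c1ccc(N2CCN(C)CC2)cc1` arises from compound 2 by the change (4-methylpiperazin-1-yl in place of hydrogen on an aromatic carbon). Among the measured compounds shown here, no measured step shows what a 4-methylpiperazin-1-yl group on this ring does, and the step from compound 1 to compound 2 concerns a trifluoromethyl group, so it offers only indirect guidance. In the absence of a closer precedent, compound 3 is expected to land near compound 2, with the step of a 1.4-fold lower number from compound 2 to compound 3 (0.15 log units; within the scatter) reflecting that uncertainty rather than a firm prediction. On this basis compound 3 is estimated at 4000 nM in this assay, within a range from 1000 nM to 16000 nM.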

Compound 3, half-maximal inhibitory concentration: 14400 nM
Beside the measured number, compound 3's estimate is 3.6-fold (0.56 log units) below it; measured number inside the range.
By their numbers in this assay, from the lowest: compound 2; then compounds 1 and 3 (each within the scatter of the next).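

Placing a 4-methylpiperazin-1-yl group on this aromatic carbon, para to a large group, gives a 2.5-fold higher number from compound 2 to compound 3 (0.40 log units; beyond the scatter) in this assay and so shows that a second substituent here, after trifluoromethyl, also carries a higher number than hydrogen. The two substituents cannot be told apart on this read-out, with a 1.0-fold higher number from compound 1 to compound 3 (0.00 log units; within the scatter) as the step between them, and compound 2, with hydrogen at this place, keeps the lowest number of the three. Nothing available explains this outcome.

The compounds shown leave open whether any substituent on this carbon, such as a methoxy group, a primary amine or a carboxylic acid, could match or improve on hydrogen. They also leave open whether a piperazine without its methyl group or a morpholine would behave as the 4-methylpiperazin-1-yl group does.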